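Amide nitrogen substitution in a cyclohexene series

The source may hold more compounds than are shown below. What is called first, only, known or untested is meant among the compounds shown, and "the series" means these compounds.

Measured so far:
compound 1 `CONC(=O)[C@@H]1CC=C(CCC=C(C)C)C[C@H]1c1ccccc1`: 2700 nM
compound 2 `CC(C)=CCCC1=CC[C@H](C(N)=O)[C@@H](c2ccccc2)C1`: > 23000 nM
compound 3 `CC(C)=CCCC1=CC[C@H](C(=O)Nc2ccc(C(=O)O)cc2)[C@@H](c2ccccc2)C1`: > 23000 nM

Going by the values given here, in an assay on isolated protein for inhibition of Apoptosis regulator Bcl-2 (Homo sapiens), read by fluorescence polarization, with stated times of 5 min and 10 min (on this read-out lower numbers stand for stronger inhibition and higher numbers for weaker inhibition), compound 1 is the only compound that gives a number, 2700 nM. The other two compounds give no number. For compound 2 the value > 23000 nM is a limit of this assay. For compound 3 the value > 23000 nM is likewise a limit. The step that the two limits leave unreadable from compound 2 to compound 3 is therefore unreadable, since both ends sit at the limit of > 23000 nM in this assay, at which 2 of the 3 values shown sit.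

Compound 4 `COC(=O)c1ccc(NC(=O)[C@@H]2CC=C(CCC=C(C)C)C[C@H]2c2ccccc2)cc1` differs from compound 1 by 4-(methoxycarbonyl)phenyl in place of methoxy on an amide-type nitrogen. Among the compounds with values here, no measured step follows the same change; the single related step is the unreadable one from compound 2 to compound 3. The expectation rests on compound 3, whose limit > 23000 nM shares the aryl-amide type of compound 4. Compound 4 is therefore expected to be weaker than compound 1 by a 4.4-fold higher number from compound 1 to compound 4 (0.65 log units; beyond the scatter), with wide uncertainty. The estimate for compound 4 is 12000 nM, between 3000 nM and 50000 nM, with a real chance that only a limit is reported.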

Compound 4, inhibition constant: > 23000 nM
Compound 4 ended at the assay's limit; the forecaster's own chance of this, stated with the estimate: 45%; at least 1.9-fold (0.28 log units) between middle value and limit.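

Going by these compounds alone, putting 4-(methoxycarbonyl)phenyl in place of methoxy on the amide-type nitrogen gives the first readable step at this position, an at least 8.5-fold higher number from compound 1 to compound 4 (0.93 log units; beyond the scatter) in the series. In this assay compound 4 gives > 23000 nM as a limit and not a number. Of the groups on this nitrogen, only methoxy, in compound 1, yields a number, and the hydrogen and both aryl groups do not: the limit of > 23000 nM in this assay, at which 3 of the 4 values shown sit.

Going by these compounds, how far compound 4 lies past its limit stays open. So does whether ethoxy or hydroxy on this nitrogen would give a number.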